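Side-chain variation on a shared epoxyquinol core

The source may report more compounds than this note shows. Statements on the series, on what has been measured and on what is new or still open speak of the compounds shown alone.

Measured so far:
compound 1 `C/C=C/C1=C(CO)[C@@H](O)[C@@H]2O[C@@H]2C1=O`: 80000 nM
compound 2 `O=C1C=C(CO)[C@H](O)[C@H]2O[C@@H]12`: > 80000 nM
compound 3 `CCCC/C=C/C1=C(CO)[C@H](O)[C@H]2O[C@H]2C1=O`: 35000 nM

In a functional assay on SKW 6.4 cells (Homo sapiens) for cytotoxicity (on this read-out higher numbers stand for weaker inhibition and lower numbers for stronger inhibition), compound 3 gives 35000 nM, the lowest of the two numbers obtained; compound 1 gives 80000 nM, a gap beyond the scatter. Compound 2 reaches only the limit of > 80000 nM in this assay, at which 1 of the 3 values shown sits, and gives no number. Compound 4 `O=C1C(/C=C/c2ccccc2)=C(CO)[C@H](O)[C@H]2O[C@@H]12` has not been measured; it differs from compound 3 by phenyl in place of butyl on a double-bonded chain carbon bound to a double-bonded chain carbon. Among the measured compounds shown here, no pair differing in one place has been measured, so the size of the step is an expectation only. Compound 4 is expected to sit close to compound 3, perhaps slightly stronger, a step of a 1.8-fold lower number from compound 3 to compound 4 (0.24 log units; within the scatter) in this assay. Compound 4 is estimated at 20000 nM, within 5000 nM to 70000 nM.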

Compound 4, half-maximal inhibitory concentration: 30000 nM
The estimate for compound 4 lay 1.5-fold (0.18 log units) below the measured number, and the stated range covers the measured number.
By their numbers in this assay, from the lowest: compounds 4 and 3 (each within the scatter of the next); then compound 1.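

Replacing butyl with phenyl on a double-bonded chain carbon bound to a double-bonded chain carbon in this assay gives a 1.2-fold lower number from compound 3 to compound 4 (0.07 log units; within the scatter) and so leaves the number effectively unmoved. Among the compounds shown here, at this position, an aromatic ring of carbon and an open butyl chain therefore read alike, which the earlier compounds could not show. Compound 2, which carries no chain at this place, gives only a limit: the limit of > 80000 nM in this assay, at which 1 of the 4 values shown sits.

From the compounds shown here alone, whether an amine or a carboxylic acid on this chain would move the number remains open. So does the effect of a longer chain, or of a substituent on the phenyl ring.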